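Epimer at the peroxide ring in a growth inhibition series

A few compounds are considered here, and "the series" means these few. Any claim that something is new, unique, unknown or untested is made for them only; others in the source may bear on it.

Measured compounds and their values:
Compound 1 `C=C1CCC[C@H]2[C@](C)(CC[C@]3(C)CC[C@@H]([C@@H](C)C(=O)O)OO3)[C@@H](C)CC[C@]12C` gives 2370 nM in a functional assay on SK-MEL-28 cells (Homo sapiens) for inhibition; a lower number here means a stronger inhibitor of growth, a higher number a weaker inhibitor of growth.
Compound 2 `CC1=C(CC/C(C)=C/CC[C@@]2(C)CC[C@@H]([C@H](C)C(=O)O)OO2)C(C)(C)CCC1` gives > 100000 nM in this assay; this is a limit of the assay, not a number.
Compound 3 `C=C1CCCC(C)(C)C1CC[C@@]1(C)CC[C@H]([C@@H](C)C(=O)O)OO1` gives > 12500 nM in this assay; this too is a limit, not a number.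

Compound 2 stands at a limit in this assay (the limit of > 100000 nM in this assay, at which 1 of the 3 values shown sits), so its position relative to compound 1 can only be stated as weaker than compound 1, without a measured size. Compound 3 also sits at a limit (the limit of > 12500 nM in this assay, at which 1 of the 3 values shown sits). Only compound 1 gives a number.

Compound 4 `CC1=C(CC/C(C)=C/CC[C@@]2(C)CC[C@H]([C@H](C)C(=O)O)OO2)C(C)(C)CCC1` is the next compound to be measured. It differs from compound 2 as follows: the two compounds have the same atoms and bonds and differ only in configuration as drawn: 1 of 4 stereo elements differ; a stereocentre at a saturated ring carbon is drawn S in compound 2 and R in compound 4. Among the compounds with values here, no step between two measured compounds of this set is a stereochemical change of this kind, so the size to expect cannot be taken from the measured pairs. Compound 2 gives only a limit, and a single inversion at a saturated ring carbon leaves the whole remaining framework unchanged. The step from compound 2 to compound 4 in this assay is expected to be an at least 1.6-fold lower number from compound 2 to compound 4 (0.22 log units; that floor lies within the scatter), with a real chance that compound 4 again returns only a limit. Compound 4 is estimated at 60000 nM, in a range from 8000 nM to 300000 nM.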

Compound 4, concentration for 50% growth inhibition: 430 nM
Beside the measured number, compound 4's estimate is 140-fold (2.14 log units) above it; measured number outside the range, below it.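

In this assay, within the data shown here, inverting a single stereocentre at a saturated ring carbon from S to R gives an at least 230-fold lower number from compound 2 to compound 4 (2.36 log units; beyond the scatter), the first readable step in this set between two compounds that differ in one place. Compound 2 gives > 100000 nM, which is a limit and not a number, so the size of this step is a floor. This carbon is therefore a position where configuration alone separates a compound at the limit from one with a measured value, and the whole step can be assigned to the inversion because no atom or bond changes: the fact that compounds 2 and 4 differ only in the configuration as drawn.

From the compounds shown here alone, whether the same inversion carries the same weight on the cores of compound 1 and compound 3 remains open, as does the effect of inverting the other stereocentres of compound 4. Also open, going by these compounds, is how much the carboxylic acid contributes in the R series, a question that a methyl ester or a primary amide in its place on compound 4 would address.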